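Swapping the aryl group on the ring nitrogen: compound 4

This account rests on a few compounds, and the source may have more. Where it says the series, first, only, none or still open, it means among the compounds named here.

Measured compounds:
- Compound 1, `O=C(Nc1ccc(Oc2ccnc3[nH]ccc23)cc1)c1cc2cccnc2n(-c2ccc(Br)cc2)c1=O`: "not determined" (no result reported)
- Compound 2, `Cn1ccc2c(Oc3ccc(NC(=O)c4cc5cccnc5n(-c5ccccc5)c4=O)cc3)ccnc21`: 560 nM
- Compound 3, `Cn1ccc2c(Oc3ccc(NC(=O)c4cc5cccnc5n(-c5ccc(Br)cc5)c4=O)cc3)ccnc21`: "not determined" (no result reported)

In a functional assay on NCI-H460 cells (Homo sapiens) for antiproliferative activity, read by MTT assay, with a stated time of 72 h (a lower number here means a stronger inhibitor, a higher number a weaker inhibitor), compound 2 gives 560 nM. Compound 3 has no single number in this assay, and compound 1 likewise has none, so the bromine-bearing compounds offer no measured anchor. For the measured compounds named here, the only number in this set is that of compound 2, whose structure differs from compound 3 on the aromatic nitrogen.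

Compound 4, `Cn1ccc2c(Oc3ccc(NC(=O)c4cc5cccnc5n(-c5ccc(C(F)(F)F)cc5Cl)c4=O)cc3)ccnc21`, is derived from compound 3 by one change: 2-chloro-4-(trifluoromethyl)phenyl in place of 4-bromophenyl on an aromatic nitrogen. Going by the values given here, the 2-chloro-4-(trifluoromethyl)phenyl group is larger than the 4-bromophenyl it replaces, but with no measured step between two compounds that differ in one place, no direction or size of effect can be read from the data. The expectation therefore rests on compound 2 alone, treated as the nearest measured relative.

Compound 4 is estimated at 700 nM in this assay, with a plausible range from 150 nM to 3500 nM.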

Compound 4, half-maximal inhibitory concentration: 6950 nM
Compound 4: middle estimate off by 9.9-fold (1.00 log units), on the low side, and the stated range ends below it.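

In this assay, putting 2-chloro-4-(trifluoromethyl)phenyl in place of phenyl on the aromatic nitrogen gives a 12-fold higher number from compound 2 to compound 4 (1.09 log units; beyond the scatter), a large step toward a weaker inhibitor and beyond the usual scatter. For the compounds shown here, this is the first readable step at this position, and it shows that the aryl group on this nitrogen can strongly change the antiproliferative reading while the rest of the molecule stays the same. No supporting data bear on what lies behind this loss.

Steps involving compound 1 or compound 3 cannot be read, so the place of 4-bromophenyl in this comparison stays unknown. Also open, on these data alone, is how much of the step belongs to the chlorine and how much to the trifluoromethyl, which entered together, and how an amine or a carboxylic acid on this aryl ring would read.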